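Swapping phenyl for cyclopropyl on the shared core

A few compounds are considered here, and "the series" means these few. Any claim that something is new, unique, unknown or untested is made for them only; others in the source may bear on it.

Among the measured compounds shown here, in a physicochemical assay for solubility, read by spectrophotometry, in phosphate buffer, with a stated time of 18 h, at pH 7.4 (a higher number here means a more soluble compound, a lower number a less soluble compound), compound 1 `CCc1ccc(-c2nc3c(c(C)nn3-c3ccccc3)c(-c3ccccc3O)c2C#N)cc1` gives 3100 nM and compound 2 `CCc1ccc(-c2nc3c(c(-c4ccccc4)nn3-c3ccccc3)c(-c3ccccc3O)c2C#N)cc1` gives 30000 nM as the higher of the two numbers so far. Compound 3 `CCc1ccc(-c2nc3c(c(C4CC4)nn3-c3ccccc3)c(-c3ccccc3O)c2C#N)cc1` has not yet been measured. Relative to compound 2, it carries cyclopropyl in place of phenyl on an aromatic carbon. For the measured compounds named here, one measured step bears on this change. Phenyl in place of methyl on that same carbon gave a 9.7-fold higher number from compound 1 to compound 2 (0.99 log units; beyond the scatter) in this assay and that step is modest but beyond the scatter. Giving up phenyl is therefore expected to move the number the other way. Going by the values given here, no compound with cyclopropyl has been measured, so the size remains uncertain. The expected change is a 3.8-fold lower number from compound 2 to compound 3 (0.57 log units; beyond the scatter) in this assay. This change may well be smaller than the measured step. The estimate for compound 3 is 8000 nM within an expected range from 2000 nM to 25000 nM in this assay when measured.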

Compound 3, solubility: 21000 nM
Compound 3: middle estimate off by 2.6-fold (0.42 log units), on the low side; the measured number falls inside the stated range.
By their numbers in this assay, from the lowest: compound 1; then compounds 3 and 2 (each within the scatter of the next).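

In this assay the change shows a 1.4-fold lower number from compound 2 to compound 3 (0.15 log units; within the scatter) and so phenyl and cyclopropyl cannot be told apart at this aromatic carbon, even though a three-membered non-aromatic ring enters where a six-membered aromatic ring leaves. The step away from methyl also holds for cyclopropyl, with a 6.8-fold higher number from compound 1 to compound 3 (0.83 log units; beyond the scatter) and so the higher number seen with phenyl does not need an aromatic ring at this carbon. Nothing measured here explains why these two rings give numbers so close together.

What the compounds shown leave open is whether any carbon ring at this position would do, or whether a longer chain such as butyl would serve as well. A group of a different kind on this carbon, such as an amine or a carboxylic acid, also remains to be placed against methyl and the two rings.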